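Swapping 4-Fluorophenyl for Thiophen-2-yl: Cytotoxicity Outlook

The source may report more compounds than this note shows. Statements on the series, on what has been measured and on what is new or still open speak of the compounds shown alone.

Compound 1 `O=C(c1ccc(F)cc1)c1ccn(-c2ccc3c(c2)B(O)OC3)c1` carries a 4-fluorophenyl group on a carbonyl carbon. In an ADME assay on L929 cells (Mus musculus) for cytotoxicity, read by resazurin assay, with a stated time of 72 h (on this read-out higher numbers stand for weaker inhibition and lower numbers for stronger inhibition), compound 1 gives only a limit of the assay, > 10 ug/mL. Compound 2 `O=C(CCCN1C(=O)c2ccccc2C1=O)c1ccn(-c2ccc3c(c2)B(O)OC3)c1` shares the same core. In this assay compound 2 likewise gives only a limit, > 10 ug/mL. Going by the values given here, both known values sit at the limit of > 10 ug/mL in this assay, at which 2 of the 2 values shown sit, so no measured step between any two compounds can be read, and compound 1 cannot be ranked against compound 2.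

Compound 3 `O=C(c1ccn(-c2ccc3c(c2)B(O)OC3)c1)c1cccs1` has not yet been measured. It differs from compound 1 in one place: thiophen-2-yl in place of 4-fluorophenyl on a carbonyl carbon. Because compound 1 sits at the limit of > 10 ug/mL in this assay, at which 2 of the 2 values shown sit, with every value shown resting at that same limit, the step that the limit leaves unreadable from compound 1 to compound 3 is expected to stay within the usual scatter, in no particular direction. Compound 3 is expected to give about 20 ug/mL in this assay, within 8 ug/mL to 60 ug/mL, most likely again reported only as a limit.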

Compound 3, half-maximal inhibitory concentration: > 10 ug/mL
Compound 3 gave a limit, no number (the forecaster's own chance of this, stated with the estimate: 80%); the middle value does not contradict the limit.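

No step from compound 1 to compound 3 can be read, because each compound gives only a limit and not a number: the limit of > 10 ug/mL in this assay, at which 3 of the 3 values shown sit.

The compounds shown leave open how compound 1, compound 2 and compound 3 rank in this assay, and whether thiophen-2-yl in place of 4-fluorophenyl changes anything there.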